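Swapping the bromine-bearing group on a shared core

The source may report more compounds than this note shows. Statements on the series, on what has been measured and on what is new or still open speak of the compounds shown alone.

In a functional assay on HeLa cells (Homo sapiens) for inhibition, read by MTT assay, with a stated time of 48 h (on this read-out lower numbers stand for stronger inhibition and higher numbers for weaker inhibition), compound 3 `CCOC(=O)C1=C(N/N=C(/Br)c2ccccc2)Nc2[nH]nc(C)c2C1c1ccc(N(C)C)cc1` reads 75700 nM and sits level, within the usual scatter, with compound 2 `CCOC(=O)C1=C(N/N=C(/Cl)c2ccc([N+](=O)[O-])cc2)Nc2[nH]nc(C)c2C1c1ccc(N(C)C)cc1` at 46200 nM on the same read-out. Compound 1 `CCOC(=O)C1=C(N/C=N/c2ncc(-c3ccccc3)s2)Nc2[nH]nc(C)c2C1c1ccc(N(C)C)cc1` stands clearly apart from both at 15400 nM with a lower number.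

Compound 4 `CCOC(=O)C1=C(N/C=N/c2ccc([N+](=O)[O-])cc2)Nc2[nH]nc(C)c2C1c1ccc(N(C)C)cc1` keeps the shared core and alters one group on an amine nitrogen. The change is a group of 11 heavy atoms (7 carbon, 2 nitrogen, 2 oxygen; one six-membered aromatic ring of carbon only) in place of a group of 9 heavy atoms (7 carbon, 1 nitrogen, 1 bromine; one six-membered aromatic ring of carbon only), on an amine nitrogen and nothing else differs.

Within the data shown here, only one measured step swaps such a group while keeping the carbon ring. It is a 1.6-fold higher number from compound 2 to compound 3 (0.21 log units; within the scatter) and it shows no clear change. That step ran roughly the opposite way, from a group with oxygen to one with bromine, so a large step seems unlikely here. Compound 1 at 15400 nM also carries no bromine, which hints at a modest drop.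

The expected change is a 2.2-fold lower number from compound 3 to compound 4 (0.34 log units; beyond the scatter) and this estimated step is small, toward lower numbers in this assay overall. Compound 4 is therefore estimated at 35000 nM with a likely range from 14000 nM to 80000 nM on this read-out.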

Compound 4, half-maximal inhibitory concentration: 57800 nM
Compound 4: middle estimate off by 1.7-fold (0.22 log units), on the low side; measured number inside the range.
By their numbers in this assay, from the lowest: compound 1; then compounds 2, 4 and 3 (each within the scatter of the next).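

Exchanging the bromine-bearing group on the amine nitrogen for the group of compound 4 gives a 1.3-fold lower number from compound 3 to compound 4 (0.12 log units; within the scatter), and exchanging the chlorine-bearing group of compound 2 gives a 1.3-fold higher number from compound 2 to compound 4 (0.10 log units; within the scatter), so in this assay these three groups, each with a carbon-only aromatic ring, read level. Among these compounds, the one clear step among the new ones comes with 4-nitrophenyl in place of 5-phenyl-1,3-thiazol-2-yl on a double-bonded nitrogen, which gives a 3.8-fold higher number from compound 1 to compound 4 (0.57 log units; beyond the scatter), so within this pair the lower number goes with the thiazole-bearing group. No measurement here accounts for either the level readings or this gap.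

From the compounds shown here alone, it remains open whether the lower number of compound 1 rests on its thiazole ring or on the phenyl group attached to that ring. Also open, going by these compounds, is what an amine or a carboxylic acid in place of the nitro group of compound 4 would do.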